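Compound 2 to compound 3: one configuration change

The compounds below may be only part of what the source reports. "The series", "measured", "known", "first", "only" and "open" are said of these compounds alone.

In a functional assay on HeLa cells (Homo sapiens) for cytotoxicity, read by MTT assay, with a stated time of 96 h (a higher number here means a weaker inhibitor, a lower number a stronger inhibitor), compound 1 `NCCC[C@H](N)CC(=O)NCCC[C@H](N)CC(=O)N[C@@H]1[C@H](O)[C@@H](O)[C@@H](COC(N)=O)O[C@H]1/N=C1\N[C@@H]2[C@H](O)CNC(=O)[C@H]2N1` reads > 10000 nM and this is a limit of the assay, not a number. In this assay compound 2 `CC(=O)N[C@@H](CCCN)CC(=O)N[C@@H]1[C@H](O)[C@@H](O)[C@@H](COC(N)=O)O[C@@H]1/N=C1\N[C@@H]2[C@H](O)CNC(=O)[C@H]2N1` reads > 10000 nM and this too is only a limit. Among the measured compounds shown here, the series so far therefore stands at the limit of > 10000 nM in this assay, at which 2 of the 2 values shown sit, and compound 2 has no number to place it by.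

Compound 3 `CC(=O)N[C@@H](CCCN)CC(=O)N[C@@H]1[C@H](O)[C@@H](O)[C@@H](COC(N)=O)O[C@H]1/N=C1\N[C@@H]2[C@H](O)CNC(=O)[C@H]2N1` changes one thing relative to compound 2: the two compounds have the same atoms and bonds and differ only in configuration as drawn: 1 of 10 stereo elements differ; a stereocentre at a saturated ring carbon is drawn S in compound 2 and R in compound 3 and a stereocentre at a saturated ring carbon is thus drawn R in compound 3 where it is drawn S in compound 2.

The expected step that the limit leaves unreadable from compound 2 to compound 3 stays within the usual scatter, with no direction expected. This expectation rests on compound 2 with its limit of > 10000 nM as the only reference. For compound 3 the estimate is 12000 nM with an expected range of 6000 nM to 30000 nM and a reading at the assay limit is the likeliest outcome.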

Compound 3, half-maximal inhibitory concentration: > 10000 nM
Compound 3 was reported as a limit; the forecaster's own chance of this, stated with the estimate: 85%; the middle value does not contradict the limit.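

In this assay, compound 2 and compound 3 are both reported only as limits of the assay, so no step can be read between them. The compounds shown leave open whether the configuration at this saturated ring carbon affects cytotoxicity at all, and how the compounds rank.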